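The source may report more compounds than this note shows. Statements on the series, on what has been measured and on what is new or still open speak of the compounds shown alone.

Measured so far:
compound 1, `Cc1ccc(S(=O)(=O)O[C@@H]2[C@@H](O)[C@H](n3cc(F)c(N)nc3=O)O[C@@H]2CO)cc1`: 8 ug/mL
compound 2, `Cc1ccc(S(=O)(=O)O[C@@H]2[C@@H](O)[C@H](n3ccc(N)nc3=O)O[C@@H]2CO)cc1`: > 100 ug/mL
compound 3, `Nc1nc(=O)n(C2OC(CO)C(Cl)C2O)cc1F`: 71 ug/mL

In a functional assay on L5178Y cells (Mus musculus) for antiproliferative activity (on this read-out higher numbers stand for weaker inhibition and lower numbers for stronger inhibition), compound 1 gives 8 ug/mL. Compound 2 gives only a limit of the assay, > 100 ug/mL; compound 2 sits at the limit of > 100 ug/mL in this assay, at which 1 of the 3 values shown sits. Compound 3 gives 71 ug/mL, the higher of the two numbers, with compound 1 giving the lower one. Compound 4, `Nc1nc(=O)n(C2OC(CO)C(Br)C2O)cc1F`, differs from compound 3 by bromo in place of chloro on a saturated ring carbon. Among the compounds with values here, the only measured step, an at least 12-fold higher number from compound 1 to compound 2 (1.09 log units; beyond the scatter), concerns hydrogen in place of fluoro on an aromatic carbon and does not bear on a bromo in place of chloro on a saturated ring carbon. No shown step informs this change, so no step beyond the scatter is expected in this assay. Compound 4 is therefore estimated at 70 ug/mL, between 30 ug/mL and 150 ug/mL, which means an expected step of a 1.0-fold lower number from compound 3 to compound 4 (0.01 log units; within the scatter).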

Compound 4, concentration for 50% inhibition: 2.6 ug/mL
Compound 4: the middle estimate sits 27-fold (1.43 log units) above what was measured, outside the stated range (below it).
By their numbers in this assay, from the lowest: compound 4; then compound 1; then compound 3. At a limit, above all of these: compound 2.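

In this assay, bromo in place of chloro on this saturated ring carbon gives a 27-fold lower number from compound 3 to compound 4 (1.44 log units; beyond the scatter). The earlier step concerned only an aromatic carbon; this one shows that exchanging one halogen for another on the saturated ring carbon, with no change in hydrogen-bond donors, acceptors or net charge, also moves the read-out beyond the scatter. Nothing measured here accounts for the step. The compounds shown leave open how iodo or an amine on this carbon would compare, and whether the bromo gain persists without the fluoro on the aromatic carbon.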